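This account rests on a few compounds, and the source may have more. Where it says the series, first, only, none or still open, it means among the compounds named here.

Measured compounds:
- Compound 1, `COc1cc2c(Oc3ccc(NC(=O)Nc4ccccc4Cl)cc3)ccnc2cc1OCCCCCCC(=O)NO`, gives 2780 nM in a functional assay on MCF7 cells (Homo sapiens) for antiproliferative activity, read by MTT assay; a higher number here means a weaker inhibitor, a lower number a stronger inhibitor.
- Compound 2, `COc1cc2c(Oc3ccc(NC(=O)Nc4ccccc4C(F)(F)F)cc3)ccnc2cc1OCCCCCCC(=O)NO`, gives 1080 nM in this assay.
- Compound 3, `COc1cc2c(Oc3ccc(NC(=O)N/N=C/c4ccccc4)cc3)ccnc2cc1OCCCCCCC(=O)NO`, gives 610 nM in this assay.

Among these three, compound 1 shows the highest number in this assay, so it is the weakest of the set: the nearest value is that of compound 2, with a 2.6-fold lower number from compound 1 to compound 2 (0.41 log units; beyond the scatter), and the furthest is that of compound 3, with a 4.6-fold lower number from compound 1 to compound 3 (0.66 log units; beyond the scatter). Compound 4, `COc1cc2c(Oc3ccc(NC(=O)N/N=C/c4ccccc4F)cc3)ccnc2cc1OCCCCCCC(=O)NO`, has not yet been measured. It differs from compound 1 in one place: a group of 9 heavy atoms (7 carbon, 1 nitrogen, 1 fluorine; one six-membered aromatic ring of carbon only) in place of a group of 7 heavy atoms (6 carbon, 1 chlorine; one six-membered aromatic ring of carbon only), on an amide-type nitrogen.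

Among the measured compounds shown here, the step that bears most directly on this change is the one from compound 1 to compound 3, where the same kind of group replaces the 2-chlorophenyl and the number falls beyond the scatter. The step from compound 1 to compound 2 also lowers the number, but more modestly. Between compound 2 and compound 3 the difference, a 1.8-fold lower number from compound 2 to compound 3 (0.25 log units; within the scatter), is within the scatter. On this basis compound 4 is expected to sit close to compound 3, with an estimated step of a 4.6-fold lower number from compound 1 to compound 4 (0.67 log units; beyond the scatter), in the direction of a stronger inhibitor. The estimate for compound 4 in this assay is 600 nM, expected to fall between 280 nM and 1300 nM.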

Compound 4, half-maximal inhibitory concentration: 1610 nM
Beside the measured number, compound 4's estimate is 2.7-fold (0.43 log units) below it, and the stated range ends below it.
By their numbers in this assay, from the lowest: compounds 3, 2, 4 and 1 (each within the scatter of the next, the first and the last beyond it).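

In this assay, the new information is the effect of fluoro in place of hydrogen on an aromatic carbon, which gives a 2.6-fold higher number from compound 3 to compound 4 (0.42 log units; beyond the scatter) and shows that this single exchange on the group at the amide-type nitrogen is enough to move the value beyond the scatter. With the fluoro present, replacing the 2-chlorophenyl no longer gives a step beyond the scatter: a 1.7-fold lower number from compound 1 to compound 4 (0.24 log units; within the scatter) lies within it, unlike the exchange without fluoro, which gave a 4.6-fold lower number from compound 1 to compound 3 (0.66 log units; beyond the scatter) and lay beyond it. The remaining step, a 1.5-fold higher number from compound 2 to compound 4 (0.17 log units; within the scatter) and also within the scatter, leaves those two compounds indistinguishable in this assay.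

Nothing among the data explains the effect of the fluoro. On these data alone, whether a chloro, methoxy or trifluoromethyl group at that aromatic carbon would behave like the fluoro remains open.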